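The source may hold more compounds than are shown below. What is called first, only, known or untested is meant among the compounds shown, and "the series" means these compounds.

Compound 1 `O=C(CSc1nc(Nc2ccccc2)c2ccccc2n1)Nc1ccccc1Cl` and compound 2 `O=C(CSc1nc(Nc2ccccc2)c2ccccc2n1)Nc1ccccc1Br` share one core, while compound 3 `C=CC(=O)Nc1cccc(NC(=O)CSc2nc(Nc3cccc(Cl)c3)c3ccccc3n2)c1` is built on another; the difference between the two cores is not broken down here. In a functional assay on PC-3 cells (Homo sapiens) for inhibition, read by MTT assay, with a stated time of 72 h (a lower number here means a stronger inhibitor, a higher number a weaker inhibitor), compound 1 gives 14600 nM, compound 2 gives 19800 nM and compound 3 gives 12300 nM. The change bromo in place of chloro on an aromatic carbon brought a 1.4-fold higher number from compound 1 to compound 2 (0.13 log units; within the scatter). Compound 4 `C=CC(=O)Nc1cccc(NC(=O)CSc2nc(Nc3cccc(Br)c3)c3ccccc3n2)c1` is not yet measured and differs from compound 3 by bromo in place of chloro on an aromatic carbon, the same kind of change, though here the place is meta to a large group whereas in the earlier pair it was ortho to a large group. For compound 4 the expected step is a 1.2-fold higher number from compound 3 to compound 4 (0.09 log units; within the scatter). This expectation rests on compound 1 and compound 2, because a 1.4-fold higher number from compound 1 to compound 2 (0.13 log units; within the scatter) stayed within the scatter. Compound 4 is estimated at 15000 nM, between 7000 nM and 35000 nM.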

Compound 4, half-maximal inhibitory concentration: 15000 nM
Beside the measured number, compound 4's estimate shows no gap at the digits printed; low and high end bracket the measured number.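

In this assay, bromo in place of chloro on an aromatic carbon gave a 1.2-fold higher number from compound 3 to compound 4 (0.09 log units; within the scatter). Set beside the earlier pair, the change reads alike on the two cores, although it sits meta to a large group in compound 4: the same change on two cores in this assay, a 1.4-fold higher number (0.13 log units; within the scatter) from compound 1 to compound 2 and a 1.2-fold higher number (0.09 log units; within the scatter) from compound 3 to compound 4, 1.1-fold (0.05 log units) apart, within the scatter of two such steps. This shows that, in these two pairs and this one assay, the swap carried over with no step beyond the scatter; it does not show that a larger effect would carry over, since neither step is large enough to test that.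

The compounds shown leave open how a fluoro, a methoxy or a nitrile would read on the same ring. They also leave open whether an amine or a carboxylic acid there would bring a step beyond the scatter on either core.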